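A chloro to fluoro swap in a small series

This account rests on a few compounds, and the source may have more. Where it says the series, first, only, none or still open, it means among the compounds named here.

Measured so far in a functional assay on HepG2 cells (Homo sapiens) for inhibition, read by MTT assay, with a stated time of 48 h; on this read-out lower numbers stand for stronger inhibition and higher numbers for weaker inhibition:
- compound 1 `COc1ccc(C(=O)C=CNc2cc(-c3ccccc3)nn2-c2ccccc2)cc1`: 2030 nM
- compound 2 `O=C(C=CNc1cc(-c2ccccc2)nn1-c1ccccc1)c1ccc(Br)cc1`: 8810 nM
- compound 3 `O=C(C=CNc1cc(-c2ccccc2)nn1-c1ccccc1)c1ccc(Cl)cc1`: 41200 nM

Compound 3 has the highest number of the three, which makes it the weakest inhibitor here, and its steps to both others lie beyond the scatter. Compound 4 `O=C(C=CNc1cc(-c2ccccc2)nn1-c1ccccc1)c1ccc(F)cc1` keeps the shared core and changes a single atom: fluoro in place of chloro on an aromatic carbon, para to a large group.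

The closest evidence is the other halogen swap, a modest one: a 4.7-fold higher number from compound 2 to compound 3 (0.67 log units; beyond the scatter). The larger moves away from methoxy, a 4.3-fold higher number from compound 1 to compound 2 (0.64 log units; beyond the scatter) and a 20-fold higher number from compound 1 to compound 3 (1.31 log units; beyond the scatter), show that changes at this place can shift the number considerably. Taken alone, the halogen swap hints at a still higher number, but it is only one step, no fluoro compound has been measured, and compound 3 already tops the series. A small move toward lower numbers is therefore expected, perhaps not beyond the scatter, and the opposite direction remains possible. The expected change is a 1.6-fold lower number from compound 3 to compound 4 (0.22 log units; within the scatter). Compound 4 is estimated at 25000 nM, with an expected range from 6000 nM to 90000 nM.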

Compound 4, half-maximal inhibitory concentration: 59900 nM
Estimate against measurement, compound 4: 2.4-fold (0.38 log units) below; low and high end bracket the measured number.
By their numbers in this assay, from the lowest: compound 1; then compound 2; then compounds 3 and 4 (each within the scatter of the next).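

In this assay the step of a 1.5-fold higher number from compound 3 to compound 4 (0.16 log units; within the scatter) lies within the scatter, so at this position on the ring the chloro and fluoro compounds cannot be told apart. The rise seen from bromo to chloro therefore does not carry on to fluoro, although bromo remains clearly separate, with a 6.8-fold higher number from compound 2 to compound 4 (0.83 log units; beyond the scatter) beyond the scatter. Methoxy stands further off still, with a 30-fold higher number from compound 1 to compound 4 (1.47 log units; beyond the scatter) also beyond the scatter, and nothing measured here explains this pattern.

Methoxy is the only group here that is not a halogen, so it remains open whether the low number of compound 1 belongs to that group alone. An amine, a hydroxyl or a longer ether chain such as ethoxy at the same place could land near compound 1 or far from it.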